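This account rests on a few compounds, and the source may have more. Where it says the series, first, only, none or still open, it means among the compounds named here.

Working notes on the series. Going by the values given here, the shared core carries an enone linking a pyrazole-bound aryl ring to a benzoyl ring, and the three measured members differ in the substitution of those two rings. Compound 1 `COc1ccc(-c2cc(/C=C/C(=O)c3ccc(N)cc3)[nH]n2)cc1` gives in a functional assay on OVCAR-4 cells (Homo sapiens) for cytotoxicity, read by sulforhodamine B assay, with a stated time of 48 h, tested at 0.01 uM (on this read-out lower numbers stand for a stronger effect and higher numbers for a weaker effect at the one concentration tested), a value of 88%. Compound 2 `COc1ccc(C(=O)/C=C/c2cc(-c3cc(OC)c(OC)c(OC)c3)n[nH]2)cc1` gives in this assay a value of 91%, and compound 3 `COc1cc(-c2cc(/C=C/C(=O)c3ccc(F)c(F)c3)[nH]n2)cc(OC)c1OC` gives in this assay a value of 90%. The three numbers lie within the scatter of one another, so compound 1 stands among them without any separation that the assay can resolve.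

Among the compounds with values here, the one single-point step available, a number 1 percentage points lower from compound 2 to compound 3 (within the scatter), concerns the benzoyl ring and is within the scatter. Compound 4 `COc1ccc(-c2cc(/C=C/C(=O)c3ccc(N)cc3)[nH]n2)cc1OC` differs from compound 1 by methoxy in place of hydrogen on an aromatic carbon. Within the data shown here, this change sits on the pyrazole-bound aryl ring, and no measured step isolates a substitution on that ring; the differences between compound 1 and compounds 2 and 3 involve both rings at once and show no movement beyond the scatter. Nothing in the numbers therefore supports a step in either direction in this assay for compound 4. The expectation is that compound 4 gives about 88%, with a range of 78% to 98%, which means an estimated step of no change at the digits printed from compound 1 to compound 4 (within the scatter).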

Compound 4, a percentage reported as activity, at one concentration (the size of the read-out at that concentration, not a potency): 85%
The estimate for compound 4 lay 3 percentage points above the measured number; the measured number falls inside the stated range.
By their numbers in this assay, from the lowest: compounds 4, 1, 3 and 2 (each within the scatter of the next).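

Going by these compounds alone, the methoxy on this aromatic carbon, ortho to a methoxy group and meta to a large group, gives the first single-place step on this six-membered aromatic ring: a number 3 percentage points lower from compound 1 to compound 4 (within the scatter). At the one concentration tested in this assay, this position therefore accepts the added methoxy with no movement that the assay can resolve, and the earlier step at a different place, a number 1 percentage points lower from compound 2 to compound 3 (within the scatter), is likewise within the scatter. No available evidence bears on this result, so the step stays an observation without an explanation.

The compounds shown leave open whether another group at this carbon, such as a hydroxyl, a fluorine, an amine or a longer ethoxy chain, would give a step beyond the scatter. They also leave open whether the added methoxy would have the same outcome on a core with a different benzoyl substitution, such as the 3,4-difluorophenyl of compound 3, and whether any separation among these compounds would appear at another concentration.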